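The compounds below may be only part of what the source reports. "The series", "measured", "known", "first", "only" and "open" are said of these compounds alone.

Three compounds sharing the core of compound 1 `O=C(CCCCCCc1ccccc1)c1ncc(-c2ccc(O)cc2)o1` have been measured in an assay (Rattus norvegicus) for inhibition of Fatty-acid amide hydrolase 1 (Homo sapiens); a lower number here means a stronger inhibitor, a higher number a weaker inhibitor. Compound 1 gives 140 nM. Compound 2 `NC(=O)c1ccc(-c2cnc(C(=O)CCCCCCc3ccccc3)o2)cc1` gives 10 nM, and compound 3 `N#Cc1ccc(-c2cnc(C(=O)CCCCCCc3ccccc3)o2)cc1` gives 40 nM. Compound 3 thus holds the second highest number of the three: the step of a 3.5-fold lower number from compound 1 to compound 3 (0.54 log units; beyond the scatter) ties it to compound 1, the step of a 4.0-fold higher number from compound 2 to compound 3 (0.60 log units; beyond the scatter) separates it from compound 2, and the step of a 14-fold lower number from compound 1 to compound 2 (1.15 log units; beyond the scatter) spans the two ends of the set.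

Compound 4 `CN(C)C(=O)c1cnc(C(=O)CCCCCCc2ccccc2)o1` differs from compound 3 by dimethylcarbamoyl in place of 4-cyanophenyl on an aromatic carbon. None of the three measured steps bears on this change: each of them exchanges one group on the six-membered aromatic ring of carbon only, whereas here that ring itself leaves and a dimethylcarbamoyl takes its place. Going by the values given here, with no measured precedent, a change this large is expected to cost potency, and the step of a 10-fold higher number from compound 3 to compound 4 (1.00 log units; beyond the scatter) is expected to be upward in number. Compound 4 is therefore estimated at 400 nM, in a wide range from 60 nM to 3000 nM.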

Compound 4, inhibition constant: 2 nM
Compound 4: the middle estimate sits 200-fold (2.30 log units) above what was measured; measured number below the stated range.
By their numbers in this assay, from the lowest: compound 4; then compound 2; then compound 3; then compound 1.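

At this carbon next to the ring oxygen, the six-membered aromatic ring of carbon only proves dispensable in this assay: dimethylcarbamoyl, which has no ring, gives a 20-fold lower number from compound 3 to compound 4 (1.30 log units; beyond the scatter), and the same exchange gives a 5.0-fold lower number from compound 2 to compound 4 (0.70 log units; beyond the scatter) against 4-carbamoylphenyl and a 70-fold lower number from compound 1 to compound 4 (1.85 log units; beyond the scatter) against 4-hydroxyphenyl. The earlier compounds shown here varied only the group carried on that aromatic ring, so they could not show that removing the ring altogether would give the lowest number of the four, with each of these steps beyond the scatter. Nothing measured here accounts for this gain.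

From the compounds shown here alone, it remains open whether the gain belongs to the carbonyl of the dimethylcarbamoyl or to its two methyl groups, and how an unsubstituted carboxamide, a methyl ester or a carboxylic acid would compare at this carbon. Going by these compounds, whether the gain would persist with a shorter chain on the ketone carbonyl is also open.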